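The source may hold more compounds than are shown below. What is called first, only, known or untested is meant among the compounds shown, and "the series" means these compounds.

In a functional assay on A549 cells (Homo sapiens) for antiproliferative activity, read by MTT assay, with a stated time of 48 h (on this read-out higher numbers stand for weaker inhibition and lower numbers for stronger inhibition), compound 1 `N#CC1=C(N)Oc2c(c3nc4ccccc4nc3c3ccccc23)C12C(=O)N(Cc1cnnn1-c1ccc(Br)cc1)c1ccccc12` gives 44300 nM. Compound 2 `N#CC1=C(N)Oc2c(c3nc4ccccc4nc3c3ccccc23)C12C(=O)N(Cc1cnnn1-c1ccc([N+](=O)[O-])cc1)c1ccccc12` differs from it by nitro in place of bromo on an aromatic carbon, and its result is a limit of this assay rather than a number: compound 2 gives > 50000 nM. That step is an at least 1.1-fold higher number from compound 1 to compound 2 (0.05 log units; that floor lies within the scatter), and it rests on (the limit of > 50000 nM in this assay, at which 1 of the 3 values shown sits). Compound 3 `N#CC1=C(N)Oc2c(N)cc3nc4ccccc4nc3c2C12C(=O)N(Cc1cnnn1-c1cccc(Br)c1)c1ccccc12` gives 18900 nM, the lower of the two numbers shown, with compound 1 the nearest and separated from it by more than the usual scatter.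

Compound 4 `Cc1ccc(-n2nncc2CN2C(=O)C3(C(C#N)=C(N)Oc4c(N)cc5nc6ccccc6nc5c43)c3ccccc32)cc1C` differs from compound 3 in one place: 3,4-dimethylphenyl in place of 3-bromophenyl on an aromatic nitrogen. Within the data shown here, the only measured step concerns a different group at a different place, the swap of bromo for nitro on an aromatic carbon, so no measured step bears on the change at the aromatic nitrogen. In this assay, therefore, no step beyond the scatter is expected, with a 1.0-fold higher number from compound 3 to compound 4 (0.00 log units; within the scatter) as the expected shift. Compound 4 is estimated at 19000 nM, within a range from 8000 nM to 45000 nM.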

Compound 4, half-maximal inhibitory concentration: > 50000 nM
Compound 4 gave a limit, no number; the forecaster's own chance of this, stated with the estimate: 10%; middle value at least 2.6-fold (0.42 log units) from the limit.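

The aromatic nitrogen does not tolerate every aryl group equally: putting 3,4-dimethylphenyl in place of 3-bromophenyl gives an at least 2.6-fold higher number from compound 3 to compound 4 (0.42 log units; beyond the scatter). Compound 4 gives > 50000 nM in this assay, which is a limit of the assay and not a number. The only earlier step could not be told from the scatter, so this is the first step shown for a change in the aryl group on that nitrogen that clearly weakens inhibition, while its full size stays unknown and the limit now weighs more heavily on the series: the limit of > 50000 nM in this assay, at which 2 of the 4 values shown sit.

The change removes the bromine and adds two methyl groups at once, so the compounds shown do not separate these two parts. On these data alone, whether a plain phenyl, a 3-methylphenyl or a phenyl bearing an amine or a carboxylic acid would match compound 3 remains open.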